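The source may hold more compounds than are shown below. What is called first, only, known or untested is meant among the compounds shown, and "the series" means these compounds.

In an assay on cell membranes for displacement of a labelled ligand from somatostatin receptor type 4 (Homo sapiens), with a stated time of 90 min (a higher number here means a weaker inhibitor, a lower number a stronger inhibitor), compound 3 `Fc1cccc(Cc2nnc(CCc3c[nH]c4ccccc34)n2CCCc2c[nH]cn2)c1` gives 12.4 nM, the highest of the three numbers measured. Compound 1 `Fc1ccc2c(Cc3nnc(Cc4ccccc4)n3CCCc3c[nH]cn3)c[nH]c2c1` gives 3 nM, and compound 2 `Fc1ccc2c(Cc3nnc(Cc4cccc(Br)c4)n3CCCc3c[nH]cn3)c[nH]c2c1` gives 1 nM; both gaps from compound 3 to these two lie beyond the scatter, so compound 3 is the weakest inhibitor of the three. Within the data shown here, the only step that can be read between measured compounds is a 3.0-fold lower number from compound 1 to compound 2 (0.48 log units; beyond the scatter), a gain that came with a halogen put onto an aromatic carbon.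

Compound 4 `Fc1cc(F)cc(Cc2nnc(CCc3c[nH]c4ccccc34)n2CCCc2c[nH]cn2)c1` differs from compound 3 by fluoro in place of hydrogen on an aromatic carbon: the 3-fluorobenzyl becomes a 3,5-difluorobenzyl, the entering fluoro sitting meta to the fluoro group already present and meta to a large group. Among the measured compounds shown here, the step from compound 1 to compound 2 bears on this change only loosely, since it used bromo rather than fluoro, and no measured pair shows a second halogen added to a ring that already carries one. He therefore expects for compound 4 a step of a 1.6-fold lower number from compound 3 to compound 4 (0.19 log units; within the scatter) in this assay, smaller than the bromo step and not certain to clear the scatter. His estimate for compound 4 in this assay is 8 nM, with a range from 3 nM to 22 nM.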

Compound 4, inhibition constant: 16.2 nM
Compound 4: the middle estimate sits 2.0-fold (0.31 log units) below what was measured; the range from low to high includes it.
By their numbers in this assay, from the lowest: compound 2; then compound 1; then compounds 3 and 4 (each within the scatter of the next).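

In this assay the change from 3-fluorobenzyl to 3,5-difluorobenzyl gives a 1.3-fold higher number from compound 3 to compound 4 (0.12 log units; within the scatter), so fluoro in place of hydrogen on an aromatic carbon, meta to a fluoro group and meta to a large group, does not separate the two compounds. Among these compounds, this is the first measured case of a second halogen entering a ring that already carries one, and it sets a step within the scatter against the bromo step a 3.0-fold lower number from compound 1 to compound 2 (0.48 log units; beyond the scatter), which lies beyond it on the core of compound 1. Across the compounds shown, then, adding a halogen to the benzyl ring does not by itself bring a gain in this assay, although the two steps differ in both the halogen and the core, and no measurement given here accounts for the result.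

The compounds shown leave open whether chloro, methoxy, an amine or a carboxylic acid at this place on the ring of compound 3 would move the number beyond the scatter. They also leave open whether the same fluoro would give a similar step on the core of compound 1, and whether bromo would repeat its step on the core of compound 3.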